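Moving a ring nitrogen and watching adenosine receptor binding

The source may hold more compounds than are shown below. What is called first, only, known or untested is meant among the compounds shown, and "the series" means these compounds.

Compound 1 `CC(C)(C)Cc1c(-c2ccoc2)sc(N)c1C(=O)c1ccc(Cl)cc1` and compound 2 `CC(C)(C)Cc1c(-c2ccncc2)sc(N)c1C(=O)c1ccc(Cl)cc1` share one core and differ only in the aromatic group fixed to a carbon of the five-membered aromatic ring with 1 sulfur. In an assay on CHO cells for displacement of a labelled ligand from adenosine receptor A3 (Homo sapiens), read by scintillation counting, tested at 10 uM (a lower number here means less inhibition, a higher number more inhibition at the concentration tested (going by the name of the read-out)), compound 1 gives 1%, and compound 2 gives 6%. Among the measured compounds shown here, the one step measured, a number 5 percentage points higher from compound 1 to compound 2 (within the scatter), is small. Compound 2 stands at the top of the two numbers shown, yet the gap to compound 1 lies within the usual scatter, so the two cannot be told apart.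

Compound 3 `CC(C)(C)Cc1c(-c2cccnc2)sc(N)c1C(=O)c1ccc(Cl)cc1` is the next variation: pyridin-3-yl in place of pyridin-4-yl on an aromatic carbon. The same atoms are kept and only the position of the ring nitrogen changes. For the measured compounds named here, the only step that bears on this, a number 5 percentage points higher from compound 1 to compound 2 (within the scatter), swapped one small aromatic ring for another at this very place and stayed within the scatter, so a change that merely moves a nitrogen within such a ring is expected to do no more. Compound 3 is therefore estimated at 5% in this assay, with a range from 0% to 20%, which corresponds to an expected a number 1 percentage points lower from compound 2 to compound 3 (within the scatter).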

Compound 3, a percentage reported as inhibition, at one concentration (the size of the read-out at that concentration, not a potency): 1%
Compound 3: the middle estimate sits 4 percentage points above what was measured; measured number inside the range.
By their numbers in this assay, from the lowest: compounds 1, 3 and 2 (each within the scatter of the next).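

Moving the ring nitrogen, with pyridin-3-yl in place of pyridin-4-yl on this aromatic carbon of the shared core, gives a number 5 percentage points lower from compound 2 to compound 3 (within the scatter) in this assay, so at this place the position of that nitrogen makes no difference that can be told from the scatter. Swapping the five-membered furan-3-yl for the six-membered pyridin-3-yl at the same carbon gives no change at the digits printed from compound 1 to compound 3 (within the scatter), so with three aromatic groups now compared here, no one of them stands apart from the others. Nothing available explains why these three numbers sit so close together.

From the compounds shown here alone, all three compounds carry an aromatic ring at this carbon, so it remains open whether an amine such as piperidine, a carboxylic acid or a longer alkyl chain at the same place would move the number beyond the scatter. Also open, going by these compounds, is whether changing the neopentyl group or the amino group, both the same across all three compounds, would alter the reading at the single concentration tested.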